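The source may report more compounds than this note shows. Statements on the series, on what has been measured and on what is new or still open speak of the compounds shown alone.

In a functional assay on Pfeiffer cells (Homo sapiens) for cytotoxicity, read by scintillation counting and thymidine incorporation, with a stated time of 4 days (a higher number here means a weaker inhibitor, a lower number a stronger inhibitor), compound 1 `COc1c([C@H](C)Nc2ncnc3[nH]cnc23)cc(Cl)c(C)c1-c1cnn(C)c1` gives 120 nM and so holds the highest number of the three measured compounds. Compound 3 `C[C@H](Nc1ncnc2[nH]cnc12)c1cc(Cl)c2cccnc2c1-c1cccc(F)c1` reads 50 nM and compound 2 `COc1c([C@H](C)Nc2ncnc(N)c2C#N)cc(Cl)c(C)c1-c1ccc(C(=O)N(C)C)cn1` reads 17 nM and both lie beyond the scatter from compound 1, yet each differs from it in more than one place, so neither value isolates a single change. Compound 4 `COc1c([C@H](C)Nc2ncnc3[nH]cnc23)cc(Cl)c(C)c1-c1cncc(S(C)(=O)=O)c1` keeps the core of compound 1 and carries 5-(methylsulfonyl)pyridin-3-yl in place of 1-methyl-1H-pyrazol-4-yl on an aromatic carbon. Going by the values given here, no measured step covers this change in this assay so only a modest lowering of the number is expected, an estimated step (a 1.7-fold lower number from compound 1 to compound 4 (0.23 log units; within the scatter)). Compound 4 is estimated at 70 nM with an expected range (20 nM to 250 nM).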

Compound 4, half-maximal inhibitory concentration: 9.5 nM
Compound 4: middle estimate off by 7.4-fold (0.87 log units), on the high side; measured number below the stated range.
By their numbers in this assay, from the lowest: compounds 4 and 2 (each within the scatter of the next); then compound 3; then compound 1.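

In this assay, going by these compounds alone, the aromatic carbon ortho to a methoxy group and ortho to a methyl group proves sensitive to what it carries: 5-(methylsulfonyl)pyridin-3-yl in place of 1-methyl-1H-pyrazol-4-yl gives a 13-fold lower number from compound 1 to compound 4 (1.10 log units; beyond the scatter) and is the first single change that can be read here. The position thus accepts the larger group with a large gain. Nothing measured here accounts for that gain.

The ring and the methylsulfonyl group change together, so their shares stay unresolved. As far as these compounds go, whether a pyridin-3-yl ring without methylsulfonyl, or one carrying a nitrile instead, would keep the gain remains open.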